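Stretching the Ether Side Chain of a Flavone Core

This account rests on a few compounds, and the source may have more. Where it says the series, first, only, none or still open, it means among the compounds named here.

Compound 1 `C=CCOc1ccc2c(=O)c(-c3cc(OC)c(OC)cc3OC)coc2c1` reaches only the limit of a functional assay on HUVEC cells (Homo sapiens) for antiproliferative activity, read by MTT assay, with a stated time of 24 h (on this read-out higher numbers stand for weaker inhibition and lower numbers for stronger inhibition), where it gives > 10000 nM. That is a limit of the measurement, not a number, so compound 1 can only be said to sit at or past the weak end of what was measured. Compound 2 `COc1cc(OC)c(-c2coc3cc(OCc4ccccc4)ccc3c2=O)cc1OC` gives 9750 nM in this assay. Compound 3 `COc1cc(OC)c(-c2coc3cc(OCc4ccc([N+](=O)[O-])cc4)ccc3c2=O)cc1OC` again returns only a limit in this assay, > 10000 nM. The three values therefore cluster around the limit; (the limit of > 10000 nM in this assay, at which 2 of the 3 values shown sit).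

Compound 4 `COc1cc(OC)c(-c2coc3cc(OCc4ccccc4C#N)ccc3c2=O)cc1OC` has not been measured. It differs from compound 1 as follows: 2-cyanophenyl in place of vinyl on a saturated chain carbon bound to an oxygen on an aromatic ring. Among the measured compounds shown here, the steps that bear on it are an at least 1.0-fold lower number from compound 1 to compound 2 (0.01 log units; that floor lies within the scatter), a change whose floor lies within the scatter, and an at least 1.0-fold higher number from compound 2 to compound 3 (0.01 log units; that floor lies within the scatter), likewise at its floor; the step that the two limits leave unreadable from compound 1 to compound 3 gives no readable size. Nothing in these steps points beyond the scatter, so compound 4 is expected to stay near the limit. Compound 4 is estimated at 10000 nM, within 5000 nM to 20000 nM. This expected outcome corresponds to a number no higher from compound 1 to compound 4 (the limit leaves the size open).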

Compound 4, half-maximal inhibitory concentration: > 10000 nM
Compound 4 was reported as a limit; the forecaster's own chance of this, stated with the estimate: 60%; the middle value sits exactly at the limit.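

In this assay, putting a cyano group onto the ring of the side chain gives an at least 1.0-fold higher number from compound 2 to compound 4 (0.01 log units; that floor lies within the scatter). The steps to compound 4 from compound 1 and from compound 3 join two limits and cannot be read. With nitro in compound 3 and cyano in compound 4, both substituted rings on this side chain now leave the reading at the limit, so replacing vinyl with 2-cyanophenyl brings no readable gain: the limit of > 10000 nM in this assay, at which 3 of the 4 values shown sit.

From the compounds shown here alone, how far past the limit compound 1, compound 3 and compound 4 really lie stays open. Also open, going by these compounds, is whether an amine or a carboxylic acid on the side-chain ring, or a longer chain in the ether, would bring the reading clearly inside the measured range.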